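The compounds below may be only part of what the source reports. "The series", "measured", "known", "first", "only" and "open" are said of these compounds alone.

Of the compounds shown here, three sharing one core have been tested in a functional assay on U-87MG ATCC cells (Homo sapiens) for cytotoxicity, read by MTT assay, with a stated time of 72 h; on this read-out higher numbers stand for weaker inhibition and lower numbers for stronger inhibition. Compound 1 `COc1cc2c(Oc3ccc(NC(=O)c4nnn(-c5ccc(F)c(F)c5)c4C(F)(F)F)cc3F)ccnc2cc1OCCCN1CCCCC1` carries a 3,4-difluorophenyl on an aromatic nitrogen, and in this assay compound 1 gives 1210 nM. Compound 2 `COc1cc2c(Oc3ccc(NC(=O)c4nnn(-c5ccc(F)cc5)c4C(F)(F)F)cc3F)ccnc2cc1OCCCN1CCC(C)CC1` carries a 4-fluorophenyl in that place and differs from compound 1 elsewhere as well; in this assay compound 2 gives 800 nM. Compound 3 `COc1cc2c(Oc3ccc(NC(=O)c4nnn(-c5ccccc5C(F)(F)F)c4C(F)(F)F)cc3F)ccnc2cc1OCCCN1CCC(C)CC1` has a 2-(trifluoromethyl)phenyl on the aromatic nitrogen, and in this assay compound 3 gives 1240 nM. Among the three numbers compound 3 gives the largest, but its gaps to compound 1 and to compound 2 both stay within the usual scatter, so the three cannot be told apart on these data.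

Compound 4 `COc1cc2c(Oc3ccc(NC(=O)c4nnn(-c5ccc(F)c(F)c5)c4C(F)(F)F)cc3F)ccnc2cc1OCCCN1CCC(C)CC1` differs from compound 3 in one place: 3,4-difluorophenyl in place of 2-(trifluoromethyl)phenyl on an aromatic nitrogen. Going by the values given here, the only measured step that touches this position is a 1.6-fold higher number from compound 2 to compound 3 (0.19 log units; within the scatter), a swap of one aromatic ring for another that left the number within the scatter. Compound 1, which carries the same 3,4-difluorophenyl as compound 4 though it differs from compound 4 elsewhere, shows a number close to that of compound 3. Both observations suggest that compound 4 is expected to move by no more than the scatter, an expected step of a 1.2-fold lower number from compound 3 to compound 4 (0.09 log units; within the scatter). For compound 4 in this assay the estimate is 1000 nM, with a range from 400 nM to 2500 nM.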

Compound 4, half-maximal inhibitory concentration: 1150 nM
Estimate against measurement, compound 4: 1.2-fold (0.06 log units) below; the range from low to high includes it.
By their numbers in this assay, from the lowest: compounds 2, 4, 1 and 3 (each within the scatter of the next).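

In this assay, replacing the 2-(trifluoromethyl)phenyl with 3,4-difluorophenyl on the aromatic nitrogen gives a small step (a 1.1-fold lower number from compound 3 to compound 4 (0.03 log units; within the scatter)), so this position has now tolerated a second swap of one aryl ring for another without leaving the scatter. Going by these compounds alone, compound 4 also connects the earlier compounds through single changes, which allows two more direct readings: fluoro in place of hydrogen on an aromatic carbon (a 1.4-fold higher number from compound 2 to compound 4 (0.16 log units; within the scatter)) and methyl in place of hydrogen on a saturated ring carbon (a 1.1-fold lower number from compound 1 to compound 4 (0.02 log units; within the scatter)), and neither of these can be told apart from repeat-measurement noise. No measurement at hand offers an explanation for why these steps are so small.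

Every group shown on this nitrogen is a phenyl ring bearing fluoro or trifluoromethyl, so it remains open whether an unsubstituted phenyl, a phenyl carrying a carboxylic acid or amine, or a short alkyl chain would keep the number in the same range. Since all the steps shown stay within the scatter, these compounds also do not reveal which kind of change at this position, if any, would move the number clearly.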